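This account rests on a few compounds, and the source may have more. Where it says the series, first, only, none or still open, it means among the compounds named here.

Measured compounds:
- compound 1 `Nc1nc(-c2ccccc2)cn1/N=C/c1cc2ccccc2nc1Cl` gives 49000 nM in a functional assay on MDA-MB-231 cells (Homo sapiens) for cytotoxicity, read by MTT assay, with a stated time of 48 h; a higher number here means a weaker inhibitor, a lower number a stronger inhibitor
- compound 2 `Cc1ccc2nc(Cl)c(/C=N/n3cc(-c4ccccc4)nc3N)cc2c1` gives 48100 nM in this assay

Compound 2 and compound 1 lie within the scatter of each other, so neither stands apart. Compound 3 `Cc1ccc2nc(Cl)c(/C=N/n3cc(-c4ccc(Cl)cc4)nc3N)cc2c1` differs from compound 2 by chloro in place of hydrogen on an aromatic carbon. Among the compounds with values here, no measured step touches this phenyl ring; the only step seen, a 1.0-fold lower number from compound 1 to compound 2 (0.01 log units; within the scatter), changed a different ring and stayed flat. With nothing pointing either way, no step beyond the scatter in this assay is expected. Compound 3 is therefore estimated at 45000 nM, with a range from 20000 nM to 100000 nM, an expected step of a 1.1-fold lower number from compound 2 to compound 3 (0.03 log units; within the scatter).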

Compound 3, half-maximal inhibitory concentration: 35200 nM
Compound 3: middle estimate off by 1.3-fold (0.11 log units), on the high side; low and high end bracket the measured number.
By their numbers in this assay, from the lowest: compounds 3, 2 and 1 (each within the scatter of the next).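

In this assay the swap of phenyl for 4-chlorophenyl, the first change seen on this ring, gives a 1.4-fold lower number from compound 2 to compound 3 (0.14 log units; within the scatter) and so compound 3 cannot be told apart from compound 2. A chloro at this place, para to a large group, therefore makes no readable difference here, and the three compounds remain one close group. Nothing measured on these compounds offers an explanation for this result. On these data alone, what stays open is whether another group at this place, such as a methoxy, an amine or a carboxylic acid, would stand clear of the scatter. As far as these compounds go, whether any change to the shared core would do so is also open.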